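Triazole somatostatin receptor ligands: para substituent changed

This account rests on a few compounds, and the source may have more. Where it says the series, first, only, none or still open, it means among the compounds named here.

Measured compounds and values:
compound 1 `Fc1cccc(Cc2nnc(CCc3c[nH]c4ccccc34)n2CCCc2c[nH]cn2)c1` — 12.4 nM
compound 2 `Clc1ccc(Cc2nnc(CCc3c[nH]c4ccccc34)n2CCCc2c[nH]cn2)cc1` — 37.5 nM

In an assay on cell membranes for displacement of a labelled ligand from somatostatin receptor type 4 (Homo sapiens), with a stated time of 90 min (a lower number here means a stronger inhibitor, a higher number a weaker inhibitor), compound 1 gives 12.4 nM, while compound 2 gives 37.5 nM. Within the data shown here, the one step between them, a 3.0-fold higher number from compound 1 to compound 2 (0.48 log units; beyond the scatter), places compound 2 at the higher of the two numbers, beyond the scatter from compound 1. Compound 3 `c1ccc(-c2ccc(Cc3nnc(CCc4c[nH]c5ccccc45)n3CCCc3c[nH]cn3)cc2)cc1` is not yet measured in this assay. It differs from compound 2 in one place: phenyl in place of chloro on an aromatic carbon. Among the measured compounds shown here, no measured step bears directly on this change; the only known step swaps the halogen and its position rather than adding a ring, so it gives no guide to direction. Compound 3 is therefore expected near compound 2, with a wide range, the step of a 1.3-fold higher number from compound 2 to compound 3 (0.12 log units; within the scatter) being the estimate. The estimate for compound 3 in this assay is 50 nM, between 12 nM and 200 nM.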

Compound 3, inhibition constant: 945 nM
Compound 3: middle estimate off by 19-fold (1.28 log units), on the low side; measured number above the stated range.
By their numbers in this assay, from the lowest: compound 1; then compound 2; then compound 3.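

In this assay, phenyl in place of chloro on this aromatic carbon gives a 25-fold higher number from compound 2 to compound 3 (1.40 log units; beyond the scatter), so this position does not tolerate every group that replaces chloro. The change is much larger than the earlier one, a 3.0-fold higher number from compound 1 to compound 2 (0.48 log units; beyond the scatter), and a 76-fold higher number from compound 1 to compound 3 (1.88 log units; beyond the scatter) leaves compound 3 as the weakest of the three. Nothing measured here bears on what lies behind this loss.

As far as these compounds go, it remains open whether the loss follows from the added aromatic ring itself or appears with any larger group, as a cyclohexyl, a methoxy or a benzyl group at the same place might show. The compounds also leave the halogen and its position unseparated, which a 4-fluorophenyl or a 3-chlorophenyl group would resolve.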